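Swapping methyl for fluoro on the benzamide ring

The source may hold more compounds than are shown below. What is called first, only, known or untested is meant among the compounds shown, and "the series" means these compounds.

Three compounds share a common core and were tested in a functional assay on U2OS cells (Homo sapiens) for antiproliferative activity, read by MTT assay, with a stated time of 72 h; a higher number here means a weaker inhibitor, a lower number a stronger inhibitor. Compound 1 `O=C(CSc1ccc(Cl)cc1)Nc1ccc2nc(NC(=O)c3ccc(C(F)(F)F)cc3)sc2c1` gives 2890 nM. Compound 2 `CCCC(=O)Nc1nc2ccc(NC(=O)CSc3ccc(Cl)cc3)cc2s1` gives 3190 nM, and compound 3 `Cc1ccc(C(=O)Nc2nc3ccc(NC(=O)CSc4ccc(Cl)cc4)cc3s2)cc1` gives 3190 nM. Compound 3 thus sits level with compound 2 at the top of the three numbers, and the step of a 1.1-fold higher number from compound 1 to compound 3 (0.04 log units; within the scatter) shows that all three are within the scatter of one another. Compound 4 `O=C(CSc1ccc(Cl)cc1)Nc1ccc2nc(NC(=O)c3ccc(F)cc3)sc2c1` differs from compound 3 by fluoro in place of methyl on an aromatic carbon. Going by the values given here, the closest precedent is the step of a 1.1-fold higher number from compound 1 to compound 3 (0.04 log units; within the scatter) at the same position, and the step of no change at the digits printed from compound 2 to compound 3 (within the scatter) likewise showed nothing beyond the scatter. Compound 4 is therefore expected at 3000 nM, with a range of 1500 nM to 6000 nM, meaning an expected step of a 1.1-fold lower number from compound 3 to compound 4 (0.03 log units; within the scatter).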

Compound 4, half-maximal inhibitory concentration: 2510 nM
Compound 4: the middle estimate sits 1.2-fold (0.08 log units) above what was measured, and the stated range covers the measured number.
By their numbers in this assay, from the lowest: compounds 4, 1, 2 and 3 (each within the scatter of the next).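

In this assay, fluoro joins methyl and trifluoromethyl at this aromatic carbon without any step beyond the scatter: a 1.3-fold lower number from compound 3 to compound 4 (0.10 log units; within the scatter), and a 1.2-fold lower number from compound 1 to compound 4 (0.06 log units; within the scatter). Putting 4-fluorophenyl in place of propyl on the carbonyl carbon gives the same picture, with a 1.3-fold lower number from compound 2 to compound 4 (0.10 log units; within the scatter). Across these four compounds, then, neither the small group on the aromatic carbon nor the group on the carbonyl carbon separates the readings.

No available evidence accounts for this flat picture. As far as these compounds go, it remains open whether an amine or a carboxylic acid on that aromatic carbon would produce a step beyond the scatter.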